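The compounds below may be only part of what the source reports. "The series", "measured", "known", "first", "only" and "open" are said of these compounds alone.

In a functional assay on HeLa cells (Homo sapiens) for antiproliferative activity, read by CCK-8 assay, with a stated time of 72 h (on this read-out lower numbers stand for stronger inhibition and higher numbers for weaker inhibition), compound 1 (`CCOC(=O)Oc1cc(-c2cncnc2-c2cc(OC)c(OC)c(OC)c2)ccc1OC`) gives 650 nM, compound 2 (`COc1ccc(-c2cncnc2-c2cc(OC)c(OC)c(OC)c2)cc1F`) gives 500 nM and compound 3 (`CCOc1ccc(-c2cncnc2-c2cc(OC)c(OC)c(OC)c2)cc1F`) gives 470 nM. Compound 2 holds the middle number of the three, and its distance to each of the other two lies within the scatter. Compound 4 (`COc1ccc(-c2cncnc2-c2cc(OC)c(OC)c(OC)c2)nc1`) differs from compound 2 by 5-methoxypyridin-2-yl in place of 3-fluoro-4-methoxyphenyl on an aromatic carbon, with 5-methoxypyridin-2-yl in place of 3-fluoro-4-methoxyphenyl. Among the measured compounds shown here, two measured steps bear on this only loosely: a 1.3-fold lower number from compound 1 to compound 2 (0.11 log units; within the scatter) and a 1.1-fold lower number from compound 2 to compound 3 (0.03 log units; within the scatter). Neither replaced the ring of carbon only with a ring holding a hetero atom, so the data give no direct size for this change. In this assay a modest move towards a higher number is expected, as a 2.4-fold higher number from compound 2 to compound 4 (0.38 log units; beyond the scatter). Compound 4 is estimated at 1200 nM, with an expected range from 300 nM to 6000 nM.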

Compound 4, half-maximal inhibitory concentration: 470 nM
Compound 4: middle estimate off by 2.6-fold (0.41 log units), on the high side; the measured number falls inside the stated range.
By their numbers in this assay, from the lowest: compounds 3, 4, 2 and 1 (each within the scatter of the next).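

In this assay, among the compounds shown here, 5-methoxypyridin-2-yl in place of 3-fluoro-4-methoxyphenyl gives a 1.1-fold lower number from compound 2 to compound 4 (0.03 log units; within the scatter), the first step here that replaces the ring of carbon only with a ring holding a hetero atom. At this aromatic carbon, ortho to a large group, the exchange leaves the number within the scatter, and the fluorine goes with it. Nothing available explains this result. Still open, from the compounds shown here alone, is how this position would respond to a pyridine ring carrying an amine, a carboxylic acid or a longer chain in place of the methoxy group.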